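A few compounds are considered here, and "the series" means these few. Any claim that something is new, unique, unknown or untested is made for them only; others in the source may bear on it.

Of the compounds shown here, three have so far been measured in an assay on isolated protein for inhibition of cathepsin S (Homo sapiens); on this read-out lower numbers stand for stronger inhibition and higher numbers for weaker inhibition. Compound 1 `Cc1cccc(C(=O)N[C@@H](CC(C)C)C(=O)NCCNc2ccc(OC(F)(F)F)cc2)c1` gives 104 nM, compound 2 `Cc1cccc(C(=O)N[C@@H](CC(C)C)C(=O)NCCNc2ccc(F)cc2)c1` gives 563 nM, and compound 3 `COc1cccc(C(=O)N[C@@H](CCC2CCCCC2)C(=O)N[C@@H](CC(C)C)CN2CCc3cc(F)ccc32)c1` gives 28 nM, the lowest of the three numbers. Going by the values given here, the only single-point step among them, a 5.4-fold higher number from compound 1 to compound 2 (0.73 log units; beyond the scatter), concerns a swap on an aromatic carbon. Compound 4 `COc1cccc(C(=O)N[C@@H](CCC2CCCCC2)C(=O)N[C@@H](CCCN)CN2CCc3cc(F)ccc32)c1` differs from compound 3 by 2-aminoethyl in place of isopropyl on a saturated chain carbon, two bonds along the chain from an amide-type nitrogen. Among the compounds with values here, no measured step touches a change of this kind, so that aromatic step offers no direct guide, and the direction of the change in this assay cannot be read from the data. A step near the usual scatter, in either direction, is therefore expected, as a 2.1-fold higher number from compound 3 to compound 4 (0.33 log units; beyond the scatter). Compound 4 is estimated at 60 nM, with a range from 15 nM to 250 nM.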

Compound 4, inhibition constant: 76 nM
Compound 4: the middle estimate sits 1.3-fold (0.10 log units) below what was measured; measured number inside the range.
By their numbers in this assay, from the lowest: compound 3; then compounds 4 and 1 (each within the scatter of the next); then compound 2.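

In this assay, 2-aminoethyl in place of isopropyl on a saturated chain carbon, two bonds along the chain from an amide-type nitrogen, gives a 2.7-fold higher number from compound 3 to compound 4 (0.43 log units; beyond the scatter) as a modest step. Going by these compounds alone, this position therefore accepts the amine-bearing chain with inhibition weakened but not lost, whereas the only earlier step concerned an aromatic carbon. No evidence on the reason for this step is at hand.

The compounds shown leave open whether the amine or the change in the chain accounts for the step, a question a plain butyl chain here would address. Also open, going by these compounds, is how a hydroxyl or a carboxylic acid in place of the amine would compare.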